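From phenethyl to 2-methylphenyl on the carbonyl carbon

The compounds below may be only part of what the source reports. "The series", "measured", "known", "first", "only" and "open" are said of these compounds alone.

In a toxicity assay on THP-1 cells (Homo sapiens) for inhibition (a higher number here means that more compound is tolerated, a lower number that less compound is tolerated), compound 3 (`COc1ccc(-c2cnc(NC(=O)CCc3ccccc3)n2C)cc1`) gives > 100000 nM as a limit, not a number. Compound 1 (`COc1ccc(-c2cnc(NC(=O)c3ncc[nH]3)n2C)cc1`) gives > 100000 nM as a limit too. Compound 2 (`CCC(=O)Nc1ncc(-c2ccc(OC)cc2)n1C`) gives > 100000 nM as a limit too. Compound 4 (`COc1ccc(-c2cnc(NC(=O)c3ccccc3C)n2C)cc1`) has 2-methylphenyl in place of phenethyl on a carbonyl carbon. Bearing on this change are a step that the two limits leave unreadable from compound 1 to compound 3 and also a step that the two limits leave unreadable from compound 1 to compound 2 on the same carbonyl carbon. The series stands at the limit of > 100000 nM in this assay, at which 3 of the 3 values shown sit, and offers no measured size. Resting on a step that the two limits leave unreadable from compound 2 to compound 3 as well, the estimated size in this assay is a number no higher from compound 3 to compound 4 (the limit leaves the size open) with nothing beyond the scatter expected. The expected value for compound 4 is 100000 nM within a range of 40000 nM to 200000 nM as estimated.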

Compound 4, half-maximal cytotoxic concentration: > 100000 nM
Compound 4 was reported as a limit; the forecaster's own chance of this, stated with the estimate: 80%; the middle value lies on the limit itself.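

The steps joining compound 4 to compound 1, compound 2 and compound 3 cannot be read, because all four values sit at one limit: the limit of > 100000 nM in this assay, at which 4 of the 4 values shown sit.

The compounds shown leave open the half-maximal cytotoxic concentration of each, and whether the group on the carbonyl carbon shifts it at all.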